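From compound 3 to compound 4: chloro for fluoro

The source may hold more compounds than are shown below. What is called first, only, known or untested is meant among the compounds shown, and "the series" means these compounds.

Within the data shown here, in an ADME assay on L929 cells (Mus musculus) for cytotoxicity, read by resazurin assay, with a stated time of 96 h (on this read-out lower numbers stand for higher toxicity in this test and higher numbers for lower toxicity in this test), compound 1 `CC(C)c1ccc(OC/C(=N\NC(N)=S)c2ccc(Br)cc2)cc1` gives 24600 nM and compound 2 `NC(=S)N/N=C(\COc1ccc(F)cc1)c1ccc(Br)cc1` gives 52300 nM as the two outer numbers so far. Compound 3 `NC(=S)N/N=C(\COc1ccc(F)c(Cl)c1)c1ccc(Br)cc1` gives 48000 nM and lies within the scatter of both, although those two differ beyond it.

Compound 4 `NC(=S)N/N=C(\COc1ccc(Cl)c(Cl)c1)c1ccc(Br)cc1` is not yet measured. It differs from compound 3 by chloro in place of fluoro on an aromatic carbon on a six-membered aromatic ring of carbon only, ortho to a chloro group and para to a large group.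

Among the measured compounds shown here, two measured steps bear on this change. Fluoro in place of isopropyl on the same carbon gave a 2.1-fold higher number from compound 1 to compound 2 (0.33 log units; beyond the scatter) and is a modest step, barely past the scatter. Chloro in place of hydrogen on the same ring gave a 1.1-fold lower number from compound 2 to compound 3 (0.04 log units; within the scatter) and stays within the scatter. Neither step is a direct precedent, as no exchange of one halogen for another has been measured.

A small shift towards a lower number is therefore expected, with no step beyond the scatter. In this assay the estimated step is a 1.2-fold lower number from compound 3 to compound 4 (0.08 log units; within the scatter) on present evidence. Compound 4 is expected at 40000 nM (estimated range 23000 nM to 66000 nM).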

Compound 4, half-maximal cytotoxic concentration: 23100 nM
Beside the measured number, compound 4's estimate is 1.7-fold (0.24 log units) above it; low and high end bracket the measured number.
By their numbers in this assay, from the lowest: compounds 4, 1, 3 and 2 (each within the scatter of the next, the first and the last beyond it).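

In this assay, among these compounds, the first exchange of one halogen for another gives a 2.1-fold lower number from compound 3 to compound 4 (0.32 log units; beyond the scatter), so the choice of halogen on this aromatic carbon moves the read-out modestly but beyond the scatter, with no change in ring, charge, or hydrogen-bond donor and acceptor counts. This carbon has now given two steps beyond the scatter, the earlier one being a 2.1-fold higher number from compound 1 to compound 2 (0.33 log units; beyond the scatter), whereas adding the chloro group to which it is ortho gave only a 1.1-fold lower number from compound 2 to compound 3 (0.04 log units; within the scatter), which lies within the scatter; these three steps are too few to make a rule, and the two at this carbon start from different neighbouring substitution. No measurement available here accounts for the difference between fluoro and chloro at this position.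

On these data alone, it remains open whether the same exchange gives a step of similar size when hydrogen replaces the chloro group to which this carbon is ortho. As far as these compounds go, it is also open how bromo, methoxy, nitrile or an amine on this carbon would stand against fluoro and chloro in this assay.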